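This account rests on a few compounds, and the source may have more. Where it says the series, first, only, none or still open, it means among the compounds named here.

Measured compounds in a functional assay on CHO cells for agonist activity at sphingosine 1-phosphate receptor 2 (Homo sapiens), read by fluorescence and calcium flux, with a stated time of 3 min; a higher number here means a weaker inhibitor, a lower number a stronger inhibitor:
- compound 1 `Cc1cc(NNC(=O)Nc2cc(Cl)nc(Cl)c2)ncc1-c1cnn(C)c1` gives > 23000 nM in this assay, a limit rather than a number
- compound 2 `CCOc1nc(Cl)cc2nc(NCc3cc(C)c(-c4cn(C)nc4C)cn3)[nH]c12` gives 4200 nM in this assay
- compound 3 `Cc1cc(CNC(=O)Nc2cc(OCC(O)CO)nc(C(F)(F)F)c2)nnc1-c1cn(C)nc1C(F)(F)F` gives < 3000 nM in this assay, again a limit rather than a number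

Where compound 3 stands: its result is a limit, (the limit of < 3000 nM in this assay, at which 1 of the 3 values shown sits), so the number itself is not known; it is one of the two limits among the three values, the other being the limit of > 23000 nM in this assay, at which 1 of the 3 values shown sits, for compound 1. Going by the values given here, compound 2 is the only compound with a measured number, and no single-point step between measured compounds exists here, so nothing is known about how such changes move this assay.

Compound 4 `Cc1cc(CNC(=O)Nc2cc(OCCO)nc(C(F)(F)F)c2)nnc1-c1cn(C)nc1C(F)(F)F` differs from compound 3 by hydrogen in place of hydroxymethyl on a saturated chain carbon bound to an oxygen on a saturated carbon and a saturated chain carbon, so that 2,3-dihydroxypropoxy becomes 2-hydroxyethoxy. The change is small and sits far from the urea and the aromatic parts. Among the compounds with values here, with no measured step to lean on, a step from compound 3 to compound 4 of a step that the limit leaves unreadable from compound 3 to compound 4 is expected, which is no more than the scatter. Compound 4 is therefore estimated at 1500 nM in this assay, within 300 nM to 8000 nM.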

Compound 4, half-maximal inhibitory concentration: 4000 nM
Beside the measured number, compound 4's estimate is 2.7-fold (0.43 log units) below it; measured number inside the range.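

Going by these compounds alone, the change from 2,3-dihydroxypropoxy to 2-hydroxyethoxy gives the first readable step in this assay, with an at least 1.3-fold higher number from compound 3 to compound 4 (0.12 log units; that floor lies within the scatter). It also gives this side-chain family its first true number, as compound 4 reads 4000 nM in this assay, so the loss of hydroxymethyl at this saturated chain carbon leaves a compound that still registers in the assay. The step is only a floor, and its true size could be larger, since compound 3 carries a limit rather than a number: the limit of < 3000 nM in this assay, at which 1 of the 4 values shown sits.

How far apart compound 3 and compound 4 really lie remains open, and no measured property of either side chain is available to explain any difference between them. Also open, as far as these compounds go, is whether an amine or a carboxylic acid in place of the hydroxyl of 2-hydroxyethoxy, or a longer chain carrying that hydroxyl, would move the number in this assay beyond the usual scatter.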